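Working notes: nitro group replaced by vinyl

The compounds below may be only part of what the source reports. "The series", "measured", "known", "first", "only" and "open" are said of these compounds alone.

Measured compounds, read in a functional assay on A549 cells (Homo sapiens) for cytotoxicity, read by CCK-8 assay, with a stated time of 24 h; on this read-out lower numbers stand for stronger inhibition and higher numbers for weaker inhibition:
Compound 1 `C/C(=C\c1cc(-c2ccccc2)cs1)C(N)=O` gives > 50000 nM, a limit of the assay.
Compound 2 `C/C(=C\c1cc(-c2ccc(F)cc2)cs1)C(N)=O` gives > 50000 nM, also a limit.
Compound 3 `C/C(=C\c1cc(-c2ccc([N+](=O)[O-])cc2)cs1)C(N)=O` gives 3500 nM.

Going by the values given here, compound 3 holds the only numerical value in this assay; the other two values sit at the limit (the limit of > 50000 nM in this assay, at which 2 of the 3 values shown sit). Compound 4 `C=Cc1ccc(-c2csc(/C=C(\C)C(N)=O)c2)cc1` differs from compound 3 by vinyl in place of nitro on an aromatic carbon. Among the compounds with values here, the steps that bear on this change are those in which the nitro group enters: an at least 14-fold lower number from compound 1 to compound 3 (1.15 log units; beyond the scatter) and an at least 14-fold lower number from compound 2 to compound 3 (1.15 log units; beyond the scatter). Taking the nitro group away again, with vinyl entering, is therefore expected to move the number back upward, and the step of an 8.6-fold higher number from compound 3 to compound 4 (0.93 log units; beyond the scatter) is estimated as a rise of roughly that size. Compound 4 is expected to give 30000 nM, in a range from 8000 nM to 100000 nM, with a fair chance that only a limit is reported.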

Compound 4, half-maximal inhibitory concentration: > 50000 nM
Compound 4: no number, only a limit; the forecaster's own chance of this, stated with the estimate: 45%; middle value at least 1.6-fold (0.22 log units) from the limit.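

Vinyl on this aromatic carbon gives an at least 14-fold higher number from compound 3 to compound 4 (1.15 log units; beyond the scatter) in this assay, so a double bond outside aromatic rings, present in both groups, is not enough to keep a measurable number at this place. Of hydrogen, fluoro, vinyl and nitro here, only nitro gives a number. The steps among compound 1, compound 2 and compound 4 cannot be read because each of these compounds gives only a limit: the limit of > 50000 nM in this assay, at which 3 of the 4 values shown sit.

Open, on these data alone, is whether nitro alone gives a number at this place, or whether an amine, a nitrile or a carboxylic acid there would also give one. As far as these compounds go, how far compound 1, compound 2 and compound 4 differ from one another also stays open.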